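Moving the Ring Along the Chain

This account rests on a few compounds, and the source may have more. Where it says the series, first, only, none or still open, it means among the compounds named here.

Compound 1, `CCCC1CCN(CCCCC(=O)c2cc(Cl)c(N)cc2OCc2cc(OC)cc(OC)c2)CC1`: in a functional assay for antagonist activity at 5-hydroxytryptamine receptor 4 (Rattus norvegicus) (on this read-out higher numbers stand for higher potency (the scale is a negative logarithm) and lower numbers for lower potency), compound 1 gives 7.7
Compound 2, `COc1cc(COc2cc(N)c(Cl)cc2C(=O)CCCCN2CCC(NS(C)(=O)=O)CC2)cc(OC)c1`: in this assay compound 2 gives 8.4

For the measured compounds named here, compound 1 stands lowest of the two numbers measured so far; its only neighbour, compound 2, lies a number 0.70 log units higher from compound 1 to compound 2 (beyond the scatter) away, a step made by swapping the group on the saturated ring. The unmeasured compound 3, `CCCCN1CCC(CCC(=O)c2cc(Cl)c(N)cc2OCc2cc(OC)cc(OC)c2)CC1`, keeps the shared core of compound 1 but differs in the linker between the carbonyl and the ring nitrogen: 1-butylpiperidin-4-yl in place of 2-(4-propylpiperidin-1-yl)ethyl on a saturated chain carbon, two bonds along the chain from a carbonyl carbon. Going by the values given here, no measured step bears directly on this rearrangement. The step from compound 1 to compound 2 touches only the substituent on the ring and leaves the placement of the ring within the chain unchanged, so there is no guide for how much the number will move. With the core kept intact, a small downward step is expected, a number 0.30 log units lower from compound 1 to compound 3 (within the scatter). Compound 3 is therefore estimated to give 7.4, with a likely range from 6.6 to 8.2.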

Compound 3, negative logarithm of the antagonist equilibrium constant: 8.9
Estimate against measurement, compound 3: 1.50 log units below, outside the stated range (above it).
By their numbers in this assay, from the lowest: compound 1; then compound 2; then compound 3.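

Until now only the group on the saturated ring had changed, and that step, a number 0.70 log units higher from compound 1 to compound 2 (beyond the scatter), was modest. Compound 3 shows that the linker matters more in this assay: putting 1-butylpiperidin-4-yl in place of 2-(4-propylpiperidin-1-yl)ethyl gives a number 1.20 log units higher from compound 1 to compound 3 (beyond the scatter) and this step is large. Both groups carry one six-membered non-aromatic ring with 1 hetero atom and no net charge, so the gain comes with a rearrangement of the same kinds of parts, though nothing measured here explains it.

Still open, from the compounds shown here alone, is whether the butyl chain itself is needed, which 1-ethylpiperidin-4-yl or 1-hexylpiperidin-4-yl would test. Also open, going by these compounds, is whether the methanesulfonamido group seen in compound 2 would add to this gain in the new arrangement.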